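Aryl imine series: outlook for the hydroxyphenyl analogue

The source may report more compounds than this note shows. Statements on the series, on what has been measured and on what is new or still open speak of the compounds shown alone.

Measured so far:
compound 1 `COc1ccc(C2C(C#N)=C(N)Oc3nc(Nc4ccc(S(N)(=O)=O)cc4)sc32)cc1` — 27500 nM in a functional assay on MCF7 cells (Homo sapiens) for cytotoxicity, read by sulforhodamine B assay, with a stated time of 48 h; on this read-out higher numbers stand for weaker inhibition and lower numbers for stronger inhibition
compound 2 `COc1ccc(C2C(C#N)=C(/N=C/c3ccc([N+](=O)[O-])cc3)Oc3nc(Nc4ccc(S(N)(=O)=O)cc4)sc32)cc1` — 9700 nM
compound 3 `COc1ccc(C2C(C#N)=C(/N=C/c3ccc(N(C)C)cc3)Oc3nc(Nc4ccc(S(N)(=O)=O)cc4)sc32)cc1` — 36200 nM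

In this assay compound 3 carries the highest number of the three. Compound 1 lies within the scatter of it, so the two cannot be ordered; compound 2 stands apart from it, as a 3.7-fold higher number from compound 2 to compound 3 (0.57 log units; beyond the scatter) shows.

Compound 4 `COc1ccc(C2C(C#N)=C(/N=C/c3ccc(O)cc3)Oc3nc(Nc4ccc(S(N)(=O)=O)cc4)sc32)cc1` differs from compound 3 by hydroxy in place of dimethylamino on an aromatic carbon. Within the data shown here, two measured steps bear on this. a 3.7-fold higher number from compound 2 to compound 3 (0.57 log units; beyond the scatter) shows that exchanging the substituent on this aryl ring can move the number beyond the scatter. a 1.3-fold higher number from compound 1 to compound 3 (0.12 log units; within the scatter) shows that adding the dimethylamino-bearing aryl imine to compound 1 changed little, whereas a 2.8-fold lower number from compound 1 to compound 2 (0.45 log units; beyond the scatter) shows a modest gain with the nitro-bearing one. Among the measured compounds shown here, no measured compound carries a hydroxy group at this position, so the direction of the change is not fixed by the data; a modest lowering at most is expected, and it may well remain within the scatter. For compound 4 the expected value is 22000 nM, with a range from 9000 nM to 55000 nM; this corresponds to an expected step of a 1.6-fold lower number from compound 3 to compound 4 (0.22 log units; within the scatter).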

Compound 4, half-maximal inhibitory concentration: 34500 nM
Compound 4: the middle estimate sits 1.6-fold (0.20 log units) below what was measured, within the range that was stated.
By their numbers in this assay, from the lowest: compound 2; then compounds 1, 4 and 3 (each within the scatter of the next).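

In this assay, hydroxy in place of dimethylamino on this aromatic carbon gives no readable change, with a 1.0-fold lower number from compound 3 to compound 4 (0.02 log units; within the scatter), so two quite different groups here cannot be told apart. Among the substituents shown, nitro alone stands apart: a 3.6-fold higher number from compound 2 to compound 4 (0.55 log units; beyond the scatter) matches the gap already seen with dimethylamino, while a 1.3-fold higher number from compound 1 to compound 4 (0.10 log units; within the scatter) puts the 4-hydroxyphenyl imine, like the 4-(dimethylamino)phenyl imine, level with the parent amino compound. No measurement at hand speaks to why these numbers fall as they do.

The compounds shown leave open whether the lower number belongs to nitro alone or extends to other groups at this place, such as trifluoromethyl or a carboxylic acid. They also leave open whether a chloro group would side with nitro or with hydroxy.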